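From 4-Cyanophenyl to 2-(Methylsulfonyl)phenyl

The compounds below may be only part of what the source reports. "The series", "measured", "known", "first", "only" and "open" are said of these compounds alone.

Of the compounds shown here, three sharing one core have been tested in a functional assay on MCF7 cells (Homo sapiens) for cytotoxicity, read by CellTiter-Glo, with a stated time of 5 days; a lower number here means a stronger inhibitor, a higher number a weaker inhibitor. Compound 1 `CC/C(=C(/c1ccc(/C=C/C(=O)O)cc1)c1ccc2[nH]ncc2c1)c1ccccc1Cl`, with a 2-chlorophenyl group, gives 2 nM. Compound 2 `CC/C(=C(/c1ccc(/C=C/C(=O)O)cc1)c1ccc2[nH]ncc2c1)c1ccc(Cl)cc1`, with a 4-chlorophenyl group, gives 15 nM. Compound 3 `CC/C(=C(/c1ccc(/C=C/C(=O)O)cc1)c1ccc2[nH]ncc2c1)c1ccc(C#N)cc1`, with a 4-cyanophenyl group, gives 47 nM, the highest number of the three and so the weakest inhibitor here.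

Compound 4 `CC/C(=C(/c1ccc(/C=C/C(=O)O)cc1)c1ccc2[nH]ncc2c1)c1ccccc1S(C)(=O)=O` changes that group: 2-(methylsulfonyl)phenyl in place of 4-cyanophenyl on a double-bonded chain carbon bound to a double-bonded chain carbon and a saturated chain carbon. Replacing 2-chlorophenyl with 4-chlorophenyl gave a 7.5-fold higher number from compound 1 to compound 2 (0.88 log units; beyond the scatter). Replacing chloro with cyano gave a 3.1-fold higher number from compound 2 to compound 3 (0.50 log units; beyond the scatter), and the two changes together gave a 24-fold higher number from compound 1 to compound 3 (1.37 log units; beyond the scatter). Within the data shown here, the closest match to the entering group is the 2-chlorophenyl of compound 1 at 2 nM, although no tested compound carries a methylsulfonyl group. A modest step to a lower number is therefore expected in this assay, with considerable uncertainty. The expected change is a 3.9-fold lower number from compound 3 to compound 4 (0.59 log units; beyond the scatter). The estimate for compound 4 is 12 nM, with an expected range of 2 nM to 60 nM.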

Compound 4, half-maximal inhibitory concentration: 70 nM
Beside the measured number, compound 4's estimate is 5.8-fold (0.77 log units) below it; the whole stated range lies below it.
By their numbers in this assay, from the lowest: compound 1; then compound 2; then compounds 3 and 4 (each within the scatter of the next).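

Compound 1's low number does not carry over to every group on that aromatic carbon: methylsulfonyl in place of chloro gives a 35-fold higher number from compound 1 to compound 4 (1.54 log units; beyond the scatter) in this assay. So 2-(methylsulfonyl)phenyl does not share the advantage of 2-chlorophenyl, giving a 4.7-fold higher number from compound 2 to compound 4 (0.67 log units; beyond the scatter) against 4-chlorophenyl and a 1.5-fold higher number from compound 3 to compound 4 (0.17 log units; within the scatter) against 4-cyanophenyl, the latter too small to separate the two groups. Nothing available explains why the methylsulfonyl compound loses so much against compound 1.

Going by these compounds, it remains open whether a methyl or fluoro group in place of the chloro of compound 1 would stay close to compound 1, which gives 2 nM, or move towards compound 4. Methylsulfonyl in place of the cyano of compound 3 would show whether the group's location matters as much for methylsulfonyl as it does for chloro.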